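A few compounds are considered here, and "the series" means these few. Any claim that something is new, unique, unknown or untested is made for them only; others in the source may bear on it.

Compound 1 `Nc1nc(NCc2ccccc2)c2ncn(/C=C3/CC3(CO)CO)c2n1` was examined in an ADME assay on Akata cells (Homo sapiens) for cytotoxicity, with a stated time of 7 days; on this read-out lower numbers stand for higher toxicity in this test and higher numbers for lower toxicity in this test. In this assay compound 1 gives only a limit, > 24000 nM. Two other compounds share the core of compound 1 and differ from it on one aromatic carbon. Compound 2 `CCCCCCCCSc1nc(N)nc2c1ncn2/C=C1/CC1(CO)CO` carries octylsulfanyl on that aromatic carbon, and in this assay compound 2 likewise gives only a limit, > 20000 nM. Compound 3 `CN(C)c1nc(N)nc2c1ncn2/C=C1/CC1(CO)CO` carries dimethylamino on that aromatic carbon, and in this assay compound 3 gives only a limit, > 24000 nM. With all three values at limits, the steps among them cannot be read: a step that the two limits leave unreadable from compound 1 to compound 2, a step that the two limits leave unreadable from compound 1 to compound 3 and a step that the two limits leave unreadable from compound 2 to compound 3. Compound 1 stands at the limit of > 24000 nM in this assay, at which 2 of the 3 values shown sit. Compound 2 stands at the limit of > 20000 nM in this assay, at which 1 of the 3 values shown sits.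

Compound 4 `CCCCOc1nc(N)nc2c1ncn2/C=C1/CC1(CO)CO` is not yet measured in this assay. It differs from compound 1 in one place: butoxy in place of benzylamino on an aromatic carbon. The measured steps that bear on this change are the three unreadable ones, which show only that exchanging benzylamino for octylsulfanyl or for dimethylamino left the value at a limit. Compound 4 is therefore expected to sit at or near such a limit as well, with an expected step that the limit leaves unreadable from compound 1 to compound 4 and no readable direction. The estimate for compound 4 in this assay is 30000 nM, within a range from 12000 nM to 80000 nM.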

Compound 4, half-maximal cytotoxic concentration: > 20000 nM
Compound 4: only a limit was reported (the forecaster's own chance of this, stated with the estimate: 80%); the middle value does not contradict the limit.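

In this assay compound 4 gives only a limit, as do compound 1, compound 2 and compound 3, so no step among these four compounds can be read. The compounds shown leave open whether any of them is toxic in this test at a measurable concentration, and whether the group on that aromatic carbon affects the value at all.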